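Swapping 3,5-dimethylphenyl for furan-2-yl in a cytotoxic series

A few compounds are considered here, and "the series" means these few. Any claim that something is new, unique, unknown or untested is made for them only; others in the source may bear on it.

- compound 1 (`COC1=C(C)C(=O)/C(=C(O)/C=C/c2ccc(O)cc2)C(=O)C1(C)C`) gives 2.9 ug/mL
- compound 2 (`CCc1ccc(/C=C/C(O)=C2/C(=O)C(C)=C(OC)C(C)(C)C2=O)cc1`) gives 5.3 ug/mL
- compound 3 (`COC1=C(C)C(=O)/C(=C(O)/C=C/c2cc(C)cc(C)c2)C(=O)C1(C)C`) gives "not determined" (no result reported)

These are the results from a functional assay on 1A9 cells (Homo sapiens) for cytotoxicity (on this read-out higher numbers stand for an effect only at larger amounts of compound and lower numbers for an effect already at smaller amounts), and they place compound 3 nowhere on the scale, since no number was reported for it. The next compound, compound 4 (`COC1=C(C)C(=O)/C(=C(O)/C=C/c2ccco2)C(=O)C1(C)C`), differs from compound 3 by one exchange (furan-2-yl in place of 3,5-dimethylphenyl on a double-bonded chain carbon bound to a double-bonded chain carbon). For the measured compounds named here, the only measured step runs (a 1.8-fold higher number from compound 1 to compound 2 (0.26 log units; within the scatter)) and stays within the scatter. That step swaps a group on an aromatic carbon and leaves the aromatic ring itself in place, so it bears only loosely on the exchange of furan-2-yl for 3,5-dimethylphenyl. Going by the values given here, with no number for compound 3, no step from it can be sized, and no direction can be expected. The best guide is the level of the two measured compounds, compound 1 (2.9 ug/mL) and compound 2 (5.3 ug/mL). In this assay compound 4 is therefore expected near 4.5 ug/mL (estimated range 1.8 ug/mL to 11 ug/mL).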

Compound 4, concentration for half-maximal effect: 7.9 ug/mL
For compound 4 the middle estimate is 1.8-fold (0.24 log units) below the measured one; the measured number falls inside the stated range.
By their numbers in this assay, from the lowest: compounds 1, 2 and 4 (each within the scatter of the next, the first and the last beyond it).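

At the place on a double-bonded chain carbon bound to a double-bonded chain carbon, the six-membered aromatic ring of carbon only can give way to furan-2-yl, a five-membered aromatic ring with 1 hetero atom, and a measured effect remains in this assay with the shared core unchanged. Against 4-ethylphenyl the exchange gives a 1.5-fold higher number from compound 2 to compound 4 (0.17 log units; within the scatter) and against 4-hydroxyphenyl it gives a 2.7-fold higher number from compound 1 to compound 4 (0.44 log units; beyond the scatter) with only the latter beyond the scatter. Nothing at hand accounts for either step.

On these data alone, compound 3 has no number, so the step from it to compound 4 cannot be read and the effect of 3,5-dimethylphenyl at this place stays unknown. As far as these compounds go, it also remains open whether thiophen-2-yl or a saturated cyclohexyl group at this place would stay at the same level.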